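Urea in place of benzamide on a pyrazole-pyridine scaffold

The compounds below may be only part of what the source reports. "The series", "measured", "known", "first", "only" and "open" are said of these compounds alone.

Measured compounds:
compound 1 `O=C(Nc1cccc(-n2cc(-c3ccncc3)c(-c3ccc(Cl)c(O)c3)n2)c1)Nc1ccc(Cl)c(Cl)c1` — 1510 nM
compound 2 `COc1cc(-c2nn(-c3cccc(NC(=O)Nc4cccc(C(F)(F)F)c4)c3)cc2-c2ccncc2)ccc1Cl` — 645 nM
compound 3 `COc1cc(-c2nn(-c3cccc(NC(=O)c4ccccc4)c3)cc2-c2ccncc2)ccc1Cl` — 661 nM

In a functional assay on U-251 cells (Homo sapiens) for inhibition, read by sulforhodamine B assay, with a stated time of 48 h (a lower number here means a stronger inhibitor of growth, a higher number a weaker inhibitor of growth), compound 3 gives 661 nM, the second highest of the three numbers; compound 2 stands nearest, compound 1 furthest. Among the compounds with values here, the one step that joins two measured compounds, a 1.0-fold higher number from compound 2 to compound 3 (0.01 log units; within the scatter), shows that exchanging the urea of compound 2 for the benzamide of compound 3 leaves this assay essentially unmoved.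

Compound 4 `COc1cc(-c2nn(-c3cccc(NC(=O)Nc4ccc(Cl)c(Cl)c4)c3)cc2-c2ccncc2)ccc1Cl` has not yet been measured. It differs from compound 3 in one place: (3,4-dichlorophenyl)amino in place of phenyl on a carbonyl carbon. This change runs back toward a urea, the direction opposite to the step from compound 2 to compound 3, which was flat. Compound 1, which also carries a (3,4-dichlorophenyl)carbamoyl group but differs elsewhere in the core, gives 1510 nM in this assay, a somewhat higher number than compound 3. With only a flat step and a weakly related neighbour to go on, no movement beyond the scatter is expected; compound 4 is estimated at 800 nM, between 300 nM and 2200 nM, corresponding to an expected step of a 1.2-fold higher number from compound 3 to compound 4 (0.08 log units; within the scatter).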

Compound 4, concentration for 50% growth inhibition: 820 nM
The estimate for compound 4 lay 1.0-fold (0.01 log units) below the measured number, within the range that was stated.
By their numbers in this assay, from the lowest: compounds 2, 3, 4 and 1 (each within the scatter of the next, the first and the last beyond it).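

In this assay, going from the benzamide back to a urea stays within the scatter (a 1.2-fold higher number from compound 3 to compound 4 (0.09 log units; within the scatter)), so on this carbonyl carbon (3,4-dichlorophenyl)amino, with its added hydrogen-bond donor, takes the place of phenyl without a readable shift. The aryl group on the urea can also be changed, since 3,4-dichlorophenyl in place of 3-(trifluoromethyl)phenyl on an amide-type nitrogen reads flat as well (a 1.3-fold higher number from compound 2 to compound 4 (0.10 log units; within the scatter)), and the benzamide and the two ureas cannot be told apart in this growth read-out. Compound 4 also gives compound 1 its first partner that differs in one place, and methyl in place of hydrogen on an oxygen on an aromatic ring likewise remains within the scatter (a 1.8-fold lower number from compound 1 to compound 4 (0.27 log units; within the scatter)).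

The compounds shown leave open whether this flat picture would hold if the aryl group on the urea gave way to a saturated amine such as piperidine, or to a chain ending in a carboxylic acid. No other measurement accompanies these numbers to say what lies behind them.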